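A Flexible Chain in Place of 2-Fluorophenyl

The source may hold more compounds than are shown below. What is called first, only, known or untested is meant among the compounds shown, and "the series" means these compounds.

Compound 1 `Nc1nn2c(O)cc(-c3ccccc3)nc2c1[N+](=O)[O-]` gives > 50 ug/mL in a functional assay on L929 cells (Mus musculus) for inhibition (on this read-out higher numbers stand for weaker inhibition of growth and lower numbers for stronger inhibition of growth), which is a limit of the assay.
Compound 2 `Nc1nn2c(O)cc(-c3ccccc3F)nc2c1[N+](=O)[O-]` gives > 50 ug/mL in this assay, again a limit of the assay.
Compound 3 `Nc1nn2c(O)cc(CNNc3ccc(F)cc3)nc2c1[N+](=O)[O-]` gives 41.4 ug/mL in this assay.

Compound 2 thus stands only at a limit, with no number of its own; it shares this with compound 1, as the limit of > 50 ug/mL in this assay, at which 2 of the 3 values shown sit, makes plain. Within the data shown here, the one step between measured compounds, a step that the two limits leave unreadable from compound 1 to compound 2, runs from one limit to another, so its size cannot be read. Among the measured compounds shown here, compound 3 is the only member of the set with a measured number, and that number lies close to the limit where the other two sit.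

Compound 4 `Nc1nn2c(O)cc(CNNC(N)S)nc2c1[N+](=O)[O-]` differs from compound 2 by (((amino(sulfanyl)methyl)amino)amino)methyl in place of 2-fluorophenyl on an aromatic carbon. For the measured compounds named here, no measured step bears directly on this change, and the limits on compound 1 and compound 2 leave no direction to lean on. What the values show is weak inhibition throughout the small set.

Compound 4 is therefore expected to give about 45 ug/mL in this assay, within 15 ug/mL to 100 ug/mL. The expected step from compound 2 to compound 4 is an at least 1.1-fold lower number from compound 2 to compound 4 (0.04 log units; that floor lies within the scatter).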

Compound 4, concentration for 50% growth inhibition: > 50 ug/mL
Compound 4 was reported as a limit; the forecaster's own chance of this, stated with the estimate: 55%; middle value at least 1.1-fold (0.04 log units) away from the limit.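

Compound 4 is a limit of the assay, so a chain with no ring on this aromatic carbon, despite the hydrogen-bond donors and acceptors counted for it, yields no measured number in this assay: the limit of > 50 ug/mL in this assay, at which 3 of the 4 values shown sit.

The steps that link compound 4 to compound 1 and compound 2 run from one limit to another and cannot be read. Among these compounds, the only readable step concerns the end of the chain: amino(sulfanyl)methyl in place of 4-fluorophenyl on an amine nitrogen gives an at least 1.2-fold higher number from compound 3 to compound 4 (0.08 log units; that floor lies within the scatter), so this pair shows no firm difference, and the chain ending in 4-fluorophenyl remains the only one here with a number of its own.

Whether the 4-fluorophenyl group on that amine nitrogen matters at all therefore stays unsettled, as does the true size of any difference hidden behind the limits. From the compounds shown here alone, how a simple amine or a carboxylic acid at the end of this chain, or a longer chain, would read on this growth test also remains open.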